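Azido for methoxy on the acetamide of compound 2

A few compounds are considered here, and "the series" means these few. Any claim that something is new, unique, unknown or untested is made for them only; others in the source may bear on it.

Working notes on a small acetamide series built on a shared core. Compound 1 `COc1cc(NCc2ccccc2)cc(OC)c1OC` carries no acyl group on the nitrogen. In a functional assay on KYSE-450 cells (Homo sapiens) for inhibition, read by MTT assay, with a stated time of 48 h (on this read-out lower numbers stand for stronger inhibition and higher numbers for weaker inhibition), compound 1 gives > 80000 nM, which is a limit of the assay rather than a number. Compound 2 `COCC(=O)N(Cc1ccc(OC)c(O)c1)c1cc(OC)c(OC)c(OC)c1` gives 460 nM in this assay. Compound 3 `C/C=C/C(=O)N(Cc1cc(OC)c(OC)c(OC)c1)c1ccc(OC)c(O)c1` gives 9160 nM in this assay, a gap from compound 2 that lies beyond the usual scatter, so compound 2 stands at the lowest of the two numbers recorded.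

Compound 4 `COc1ccc(CN(C(=O)CN=[N+]=[N-])c2cc(OC)c(OC)c(OC)c2)cc1O` is not yet measured. It differs from compound 2 by azido in place of methoxy on a saturated chain carbon bound to a carbonyl carbon. The change keeps the carbonyl and the saturated chain carbon bound to it, and exchanges one small chain substituent for another.

Among the measured compounds shown here, the measured values offer no step of this kind. The expectation therefore rests on compound 2 alone, whose 460 nM is taken as the anchor. The expected step is a 1.3-fold higher number from compound 2 to compound 4 (0.12 log units; within the scatter), within the scatter and in no set direction. Compound 4 is estimated at 600 nM, with a range from 150 nM to 2500 nM.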

Compound 4, half-maximal inhibitory concentration: 160 nM
The estimate for compound 4 lay 3.8-fold (0.57 log units) above the measured number, and the stated range covers the measured number.
By their numbers in this assay, from the lowest: compound 4; then compound 2; then compound 3. At a limit, above all of these: compound 1.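

Read in this assay the exchange of methoxy for azido gives a 2.9-fold lower number from compound 2 to compound 4 (0.46 log units; beyond the scatter) and so shows that the substituent on this saturated chain carbon bound to a carbonyl carbon can be changed with inhibition kept, and here somewhat strengthened. Among the compounds shown here, the earlier compounds held no pair differing in one place, so this is the first reading of what this substituent alone does to the number. No measurement shown bears on the reason for this step.

On these data alone, a single exchange sets no trend, so it remains open whether an amine or a carboxylic acid on this chain carbon would keep the lower number. Also open, as far as these compounds go, is whether a longer chain carrying the azido group would do the same.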